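Swapping the Side Chain on a Weak Histamine Binder

The source may hold more compounds than are shown below. What is called first, only, known or untested is meant among the compounds shown, and "the series" means these compounds.

Compound 1 `CC(C)(C)OC[C@@H](N)C(=O)N1CCN(CCCOc2ccc(C(=O)C3CC3)cc2)CC1` and compound 2 `CC(C)N[C@H](C)C(=O)N1CCN(CCCOc2ccc(C(=O)C3CC3)cc2)CC1` share one core and differ only in the group on the carbonyl carbon. In an assay for binding affinity to histamine H2 receptor (Homo sapiens) (a lower number here means a stronger inhibitor, a higher number a weaker inhibitor), compound 1 gives 45700 nM, and compound 2 gives 50100 nM; the step of a 1.1-fold higher number from compound 1 to compound 2 (0.04 log units; within the scatter) places the two within the scatter of each other, so compound 1 holds the lowest of the two numbers without standing apart from compound 2. Compound 3 `N[C@H](CC1CCCCC1)C(=O)N1CCN(CCCOc2ccc(C(=O)C3CC3)cc2)CC1` is not yet measured. Relative to compound 1 it carries cyclohexyl in place of tert-butoxy on a saturated chain carbon, two bonds along the chain from an amine nitrogen and a carbonyl carbon. Going by the values given here, the only step that bears on this, a 1.1-fold higher number from compound 1 to compound 2 (0.04 log units; within the scatter), changed the same region of the molecule and moved the number hardly at all, so a change at this position is expected to stay within the scatter, with no direction favoured. Compound 3 is therefore estimated at 40000 nM, within 15000 nM to 120000 nM, a step of a 1.1-fold lower number from compound 1 to compound 3 (0.06 log units; within the scatter).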

Compound 3, inhibition constant: 20400 nM
Estimate against measurement, compound 3: 2.0-fold (0.29 log units) above, within the range that was stated.
By their numbers in this assay, from the lowest: compound 3; then compounds 1 and 2 (each within the scatter of the next).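

In this assay, going by these compounds alone, the first step in this region had stayed within the scatter, but cyclohexyl in place of tert-butoxy gives a 2.2-fold lower number from compound 1 to compound 3 (0.35 log units; beyond the scatter) and so shows that the group on this saturated chain carbon can move the number beyond it. Against compound 2, the change to 1-amino-2-cyclohexylethyl gives a 2.5-fold lower number from compound 2 to compound 3 (0.39 log units; beyond the scatter), which places compound 3 apart from both earlier compounds, though both steps are only modest. No measurement offered here accounts for this gain.

The compounds shown leave open whether the gain follows from the ring of carbon or simply from the loss of the ether oxygen, a question that phenyl, cyclopentyl or an open hexyl chain on the same carbon would help to settle. They also leave open how a carboxylic acid in place of the amine would read in this assay.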